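A Hydroxyalkyl Amide Rearranged: Compound 2 to Compound 3

The source may report more compounds than this note shows. Statements on the series, on what has been measured and on what is new or still open speak of the compounds shown alone.

Two compounds share one core and differ only in the group on the amide-type nitrogen. Compound 1 `CCn1c(C(=O)NCC(=O)OC)ccc1C(CC)(CC)c1ccc(OCS(=O)(=O)c2ccccc2)c(C)c1` carries a (methoxycarbonyl)methyl group there. In a functional assay on MCF7 cells (Homo sapiens) for antiproliferative activity, read by MTT assay, with a stated time of 24 h (a lower number here means a stronger inhibitor, a higher number a weaker inhibitor), compound 1 gives only a limit, > 50000 nM, and no number. Compound 2 `CCn1c(C(=O)N[C@@H](C)CO)ccc1C(CC)(CC)c1ccc(OCS(=O)(=O)c2ccccc2)c(C)c1` carries a 1-(hydroxymethyl)ethyl group on the same nitrogen, and in this assay compound 2 gives 10800 nM. Among the measured compounds shown here, the step of an at least 4.6-fold lower number from compound 1 to compound 2 (0.66 log units; beyond the scatter) is the only measured step, and it is the only place where compound 2 can be set against another compound; its partner sits at the limit of > 50000 nM in this assay, at which 1 of the 2 values shown sits.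

Compound 3 `CCn1c(C(=O)NCCCO)ccc1C(CC)(CC)c1ccc(OCS(=O)(=O)c2ccccc2)c(C)c1` is the unmeasured compound. The change from compound 2 is 3-hydroxypropyl in place of 1-(hydroxymethyl)ethyl on an amide-type nitrogen. No measured step compares two hydroxyalkyl groups of this kind, so the step from compound 1 to compound 2 bears on this change only loosely, and there is no reason from the numbers to expect a step beyond the scatter in either direction. Compound 3 is therefore expected to give about 12000 nM in this assay, within a range from 4000 nM to 40000 nM. The expected step of a 1.1-fold higher number from compound 2 to compound 3 (0.05 log units; within the scatter) means essentially no change.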

Compound 3, half-maximal inhibitory concentration: 42000 nM
Beside the measured number, compound 3's estimate is 3.5-fold (0.54 log units) below it, and the stated range ends below it.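

In this assay, the group on the amide-type nitrogen proves sensitive to how its atoms are joined, and not only to which atoms are present: moving from 1-(hydroxymethyl)ethyl to 3-hydroxypropyl gives a 3.9-fold higher number from compound 2 to compound 3 (0.59 log units; beyond the scatter). The two groups have the same heavy atoms and the same counts of hydrogen-bond donors and acceptors, so those counts do not separate them; they differ in the way the chain is joined, and only 1-(hydroxymethyl)ethyl has a defined stereocentre. Compound 1 remains a limit of the assay and not a number, so an at least 1.1-fold lower number from compound 1 to compound 3 (0.07 log units; that floor lies within the scatter) cannot be read as an order between the two: the limit of > 50000 nM in this assay, at which 1 of the 3 values shown sits.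

The compounds shown leave open whether the lower number of compound 2 goes with the branched chain itself or with its particular stereocentre, which the mirror-image 1-(hydroxymethyl)ethyl group would help to separate. From the compounds shown here alone, how a longer chain such as 4-hydroxybutyl, or an amine or a carboxylic acid in place of the hydroxyl group, would read in this assay also stays open.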